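The source may hold more compounds than are shown below. What is called first, only, known or untested is meant among the compounds shown, and "the series" means these compounds.

Compound 1 `CC1(C)Cc2c(sc(NC(=O)c3ccn[nH]3)c2C(N)=O)C(C)(C)O1` carries a 1H-pyrazol-5-yl group on a carbonyl carbon. For the measured compounds named here, in an assay on cells for positive allosteric modulation of Cystic fibrosis transmembrane conductance regulator variant F508del (Homo sapiens), with stated times of 10 min and 7 s, in the presence of a further agent that is not named here (on this read-out lower numbers stand for an effect already at smaller amounts and higher numbers for an effect only at larger amounts of compound), compound 1 gives 3 nM, the lowest of the three numbers measured so far. Compound 2 `CC1(C)Cc2c(sc(NC(=O)C3CCNC3=O)c2C(N)=O)C(C)(C)O1` gives 101 nM and compound 3 `CC1(C)Cc2c(sc(NC(=O)C(C)(C)O)c2C(N)=O)C(C)(C)O1` gives 16 nM; the steps of a 34-fold higher number from compound 1 to compound 2 (1.53 log units; beyond the scatter) and a 5.3-fold higher number from compound 1 to compound 3 (0.73 log units; beyond the scatter) each exchange the whole group on the carbonyl carbon. Compound 4 `CC1(C)Cc2c(sc(NC(=O)c3cc(C(F)(F)F)n[nH]3)c2C(N)=O)C(C)(C)O1` keeps that group and differs from compound 1 only by trifluoromethyl in place of hydrogen on an aromatic carbon. Going by the values given here, none of the measured steps tries a small addition of this kind, so they give little direct guidance; the group that gave the lowest number stays in place. The step of a 1.3-fold higher number from compound 1 to compound 4 (0.12 log units; within the scatter) is therefore expected to be small, possibly none beyond the scatter. Compound 4 is estimated at 4 nM, with a range from 1.5 nM to 12 nM.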

Compound 4, half-maximal effective concentration: 3 nM
Compound 4: the middle estimate sits 1.3-fold (0.12 log units) above what was measured; low and high end bracket the measured number.
By their numbers in this assay, from the lowest: compounds 1 and 4 (each within the scatter of the next); then compound 3; then compound 2.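

In this assay this aromatic carbon of the 1H-pyrazol-5-yl group accepts trifluoromethyl, 4 heavy atoms in place of a hydrogen, with no change at the digits printed from compound 1 to compound 4 (within the scatter) as the outcome. The substituted group also stays ahead of the other two groups on the carbonyl carbon, with a 5.3-fold lower number from compound 3 to compound 4 (0.73 log units; beyond the scatter) and a 34-fold lower number from compound 2 to compound 4 (1.53 log units; beyond the scatter) as the two comparisons. Nothing given here explains why the addition leaves the number in place. On these data alone, whether this carbon would accept an amine, a carboxylic acid or a longer chain in the same way remains open.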